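From 2,4-Difluorobenzyl to 2,6-Difluorobenzyl

The source may hold more compounds than are shown below. What is called first, only, known or untested is meant among the compounds shown, and "the series" means these compounds.

In a functional assay on SW 1116 cells (Homo sapiens) for antiproliferative activity, read by MTT assay, with a stated time of 48 h (a lower number here means a stronger inhibitor, a higher number a weaker inhibitor), three compounds sharing one core have been measured. Compound 1 `Clc1ccccc1CSc1nnc(-c2cnccn2)n1-c1ccccc1` gives 18100 nM and compound 2 `Clc1ccc(CSc2nnc(-c3cnccn3)n2-c2ccccc2)cc1` gives 12500 nM, with a 1.4-fold lower number from compound 1 to compound 2 (0.16 log units; within the scatter). Compound 3 `Fc1ccc(CSc2nnc(-c3cnccn3)n2-c2ccccc2)c(F)c1` is the strongest of the three, at 4650 nM.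

Compound 4 `Fc1cccc(F)c1CSc1nnc(-c2cnccn2)n1-c1ccccc1` has the same atoms as compound 3, joined differently: 2,6-difluorophenyl in place of 2,4-difluorophenyl on a saturated chain carbon bound to a sulfur. Among the compounds with values here, no measured compound other than compound 3 carries a difluorophenyl group, and none carries the 2,6-difluorophenyl group, so no measured step matches this change. The nearest evidence is two modest steps at the same place, a 3.9-fold lower number from compound 1 to compound 3 (0.59 log units; beyond the scatter) and a 2.7-fold lower number from compound 2 to compound 3 (0.43 log units; beyond the scatter). These show that changes on this saturated chain carbon bound to a sulfur have so far been modest in size. Since compound 3 holds the lowest number, a modest rise seems more likely than a further fall, although a change within the scatter remains possible. The expected change is a 1.6-fold higher number from compound 3 to compound 4 (0.21 log units; within the scatter). For compound 4, the estimated value is 7500 nM, with an expected range of 2800 nM to 18000 nM.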

Compound 4, half-maximal inhibitory concentration: 24100 nM
The estimate for compound 4 lay 3.2-fold (0.51 log units) below the measured number, and the stated range ends below it.
By their numbers in this assay, from the lowest: compound 3; then compounds 2, 1 and 4 (each within the scatter of the next).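

Swapping the 2,4-difluorophenyl group for the 2,6-difluorophenyl group on a saturated chain carbon bound to a sulfur leaves the atoms and the counted features unchanged, yet in this assay it gives a 5.2-fold higher number from compound 3 to compound 4 (0.71 log units; beyond the scatter). Two fluorines on the ring are therefore not enough in themselves to give the lower number, since the 2,6-difluorophenyl group stays within the scatter of both chlorophenyl groups, with a 1.9-fold higher number from compound 2 to compound 4 (0.29 log units; within the scatter) and a 1.3-fold higher number from compound 1 to compound 4 (0.12 log units; within the scatter). No measurement at hand explains why the two difluorophenyl groups differ.

On these data alone, it remains open whether the 2,4-difluorophenyl result extends to related groups at this place, such as 2,4-dichlorophenyl or 4-methoxyphenyl. As far as these compounds go, it is also open whether a pyridine ring or a plain alkyl chain would be tolerated there in place of the phenyl ring.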